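A few compounds are considered here, and "the series" means these few. Any claim that something is new, unique, unknown or untested is made for them only; others in the source may bear on it.

Of the compounds shown here, three have numbers so far in a functional assay for inhibition; a higher number here means a weaker inhibitor, a lower number a stronger inhibitor. Compound 1 (`Nc1ccc(S(=O)(=O)N(Cc2ccc(Br)cc2F)c2cc(F)c(O)c(F)c2)cc1`) gives 73100 nM, compound 2 (`O=S(=O)(Nc1cc(F)c(O)c(F)c1)c1ccc(C(F)(F)F)cc1`) gives 66000 nM, and compound 3 (`CCNC(=O)Nc1ccc(S(=O)(=O)Nc2cc(F)c(O)c(F)c2)cc1`) gives 81700 nM. These numbers lie within the scatter of one another, so compound 1 cannot be placed above or below the other two.

Compound 4 (`O=S(=O)(c1ccccc1)N(Cc1ccc(Br)cc1F)c1cc(F)c(O)c(F)c1`) differs from compound 1 in one place: hydrogen in place of amino on an aromatic carbon. Put simply, this is hydrogen in place of amino on an aromatic carbon, which turns 4-aminophenyl into phenyl.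

Within the data shown here, no measured step removes an amino group. The closest evidence is one exchange of a group on an aromatic carbon, with (ethylcarbamoyl)amino in place of trifluoromethyl, and it gives a 1.2-fold higher number from compound 2 to compound 3 (0.09 log units; within the scatter). Among the measured compounds shown here, this is only a single step, and compound 2 and compound 3 also differ from compound 1 elsewhere, so it offers modest guidance. Even so, it gives no reason to expect a large shift, and no step beyond the scatter is expected in this assay, in either direction. The estimated step is a 1.0-fold lower number from compound 1 to compound 4 (0.02 log units; within the scatter). For compound 4 the expected value is 70000 nM, with an estimated range from 32000 nM to 150000 nM.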

Compound 4, half-maximal inhibitory concentration: 66000 nM
Estimate against measurement, compound 4: 1.1-fold (0.03 log units) above, within the range that was stated.
By their numbers in this assay, from the lowest: compounds 2, 4, 1 and 3 (each within the scatter of the next).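

Compound 4 carries no group at all at this position, only hydrogen, so the comparison with compound 1 tests the amino group itself rather than an exchange of one group for another. In this assay, losing the amino group gives a 1.1-fold lower number from compound 1 to compound 4 (0.04 log units; within the scatter), so on the core of compound 1 this group, with its hydrogen-bond donor and acceptor, makes no difference that can be told from the usual scatter of repeated measurements. The earlier step between compound 2 and compound 3 could not show this, since it swapped one group for another on a different core, and nothing measured here explains why the amino group can go without a clear change in the number.

The compounds shown leave open whether a carboxylic acid, a methoxy group or a longer chain at this same place on the phenyl ring of compound 4 would move the number beyond the scatter. Among these compounds, they also leave open which part of the shared core, if any, can move the number, since every step so far stays within the scatter.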